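This account rests on a few compounds, and the source may have more. Where it says the series, first, only, none or still open, it means among the compounds named here.

Of the compounds shown here, two have so far been measured in an assay for inhibition of protein disulfide-isomerase (Homo sapiens), with a stated time of 1 h; on this read-out higher numbers stand for weaker inhibition and lower numbers for stronger inhibition. Compound 1 `Cc1ccnc(NC(c2ccc([N+](=O)[O-])cc2)c2ccc3cccnc3c2O)c1` gives 530 nM in this assay. Compound 2 `Oc1ccc2[nH]ncc2c1C(c1ccc(-n2cccc2)cc1)N1CCCCC1` gives 290 nM in this assay, which is the lower of the two numbers, although the gap to compound 1 lies within the usual scatter of such measurements, so no order between them can be claimed. Compound 3 `Oc1ccc2[nH]ncc2c1C(c1ccc(C(F)(F)F)cc1)N1CCCCC1` has not yet been measured. Compound 3 differs from compound 2 in one place: trifluoromethyl in place of 1H-pyrrol-1-yl on an aromatic carbon. For the measured compounds named here, no pair of measured compounds differing in a single place is available. Going by the values given here, this change therefore has no precedent among the compounds at hand. Only a small step is expected, a 1.6-fold higher number from compound 2 to compound 3 (0.19 log units; within the scatter), a slight weakening that stays within the scatter. Compound 3 is accordingly estimated at 450 nM in this assay, with a range from 120 nM to 1700 nM.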

Compound 3, half-maximal inhibitory concentration: 710 nM
Estimate against measurement, compound 3: 1.6-fold (0.20 log units) below, and the stated range covers the measured number.
By their numbers in this assay, from the lowest: compounds 2, 1 and 3 (each within the scatter of the next, the first and the last beyond it).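

In this assay, for the compounds shown here, the exchange gives the first readable step between compounds differing in one place: a 2.4-fold higher number from compound 2 to compound 3 (0.39 log units; beyond the scatter). It shows that the aromatic carbon para to a large group is not indifferent to what it carries, since with the rest of the structure unchanged, trifluoromethyl in place of 1H-pyrrol-1-yl shifts the read-out modestly towards weaker inhibition. Nothing among the data shown explains why the number rises. A single exchange cannot separate the loss of the five-membered aromatic ring from the arrival of trifluoromethyl itself. Where a phenyl ring, an amine or a carboxylic acid in this place would fall relative to compound 2 and compound 3 remains open, as does the effect of a plain hydrogen there.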